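Methylsulfanyl for Hydroxyethyl on a Shared Triazolopyrimidine-Type Core

The compounds below may be only part of what the source reports. "The series", "measured", "known", "first", "only" and "open" are said of these compounds alone.

Measured compounds:
compound 1 `Cc1cc(Nc2ccc(C(F)(F)F)cc2)n2nc(CCO)nc2n1` gives 19000 nM
compound 2 `COCc1nc2nc(C)cc(Nc3ccc(S(F)(F)(F)(F)F)cc3)n2n1` gives 63000 nM

In a physicochemical assay for solubility, at pH 6.5 (on this read-out higher numbers stand for higher solubility and lower numbers for lower solubility), compound 1 gives 19000 nM, the lowest of the two numbers; compound 2 gives 63000 nM, which stands beyond the scatter above it. Compound 3 `CSc1nc2nc(C)cc(Nc3ccc(C(F)(F)F)cc3)n2n1` has not been measured in this assay. It differs from compound 1 in one place: methylsulfanyl in place of 2-hydroxyethyl on an aromatic carbon. Among the measured compounds shown here, no measured pair shows this same change, so the size of the step rests on expectation alone. The donor that leaves is not replaced, and a lower number than that of compound 1 is expected, with the step from compound 1 to compound 3 in this assay estimated as a 3.2-fold lower number from compound 1 to compound 3 (0.50 log units; beyond the scatter), likely beyond the scatter. For compound 3 the expected solubility is 6000 nM, with a range from 1500 nM to 25000 nM.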

Compound 3, solubility: 19000 nM
Estimate against measurement, compound 3: 3.2-fold (0.50 log units) below; the measured number falls inside the stated range.
By their numbers in this assay, from the lowest: compounds 1 and 3 (each within the scatter of the next); then compound 2.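

Compounds 1 and 2 differ in more than one place, so neither could speak for this position alone. In this assay the new pair shows no change at the digits printed from compound 1 to compound 3 (within the scatter) when methylsulfanyl takes the place of 2-hydroxyethyl on the aromatic carbon between two ring nitrogen atoms. The group that leaves counts one hydrogen-bond donor and the group that enters counts none, so in this single pair the loss of that donor comes with no readable shift. Nothing measured here accounts for the two groups reading alike.

Going by these compounds, whether an amine, a carboxylic acid or a longer chain at the same place would read the same stays open. So does whether this change would again leave the read-out in place on a compound differing elsewhere from compound 1.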